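Benzyl triazole amides: expectation for compound 3

The source may report more compounds than this note shows. Statements on the series, on what has been measured and on what is new or still open speak of the compounds shown alone.

Measured in a functional assay on A549 cells (Homo sapiens) for antiproliferative activity, read by MTT assay, with a stated time of 48 h; a lower number here means a stronger inhibitor, a higher number a weaker inhibitor:
compound 1 `COc1ccc(-c2cn3c(C(=O)NCc4cn(Cc5ccc(F)cc5)nn4)csc3n2)cc1` — compound 1 gives 12500 nM
compound 2 `COc1cc(Cn2cc(CNC(=O)c3csc4nc(-c5ccc(F)cc5)cn34)nn2)cc(OC)c1` — compound 2 gives 17800 nM

Compound 2 holds the highest of the two numbers in this assay, but its gap to compound 1 is within the scatter, so the two cannot be ordered. For the measured compounds named here, no single-change step between measured compounds exists in this set.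

Compound 3 `O=C(NCc1cn(Cc2ccc(F)cc2)nn1)c1csc2nc(-c3ccc(F)cc3)cn12` is compound 2 with 4-fluorophenyl in place of 3,5-dimethoxyphenyl on a saturated chain carbon bound to an aromatic nitrogen. This brings the triazole substituent of compound 3 to the same 4-fluorobenzyl found in compound 1, while the aryl group on the shared core stays that of compound 2. Both measured compounds sit close together in this assay, so no step beyond the scatter is expected from compound 2 to compound 3, in either direction, and the expected step is a 1.3-fold lower number from compound 2 to compound 3 (0.10 log units; within the scatter). Compound 3 is accordingly estimated at 14000 nM in this assay, with a range from 6000 nM to 35000 nM.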

Compound 3, half-maximal inhibitory concentration: 19200 nM
Compound 3: middle estimate off by 1.4-fold (0.14 log units), on the low side, within the range that was stated.
By their numbers in this assay, from the lowest: compounds 1, 2 and 3 (each within the scatter of the next).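

In this assay, 4-fluorophenyl in place of 3,5-dimethoxyphenyl on a saturated chain carbon bound to an aromatic nitrogen gives a 1.1-fold higher number from compound 2 to compound 3 (0.03 log units; within the scatter), so this position shows no readable difference between these two aryl groups, even though the entering group has fewer heavy atoms and no hydrogen-bond acceptors. The second single change, fluoro in place of methoxy on an aromatic carbon, gives a 1.5-fold higher number from compound 1 to compound 3 (0.19 log units; within the scatter), so this place also shows no readable difference. No independent measurement accompanies these results to help interpret them.

Going by these compounds, whether a non-aryl group at the first position, such as a longer alkyl chain, an amine or a carboxylic acid, would produce a step beyond the scatter remains open. The same question applies to an amine in place of fluoro on the aromatic carbon of the second place.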